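Swapping the Group Beside the Ester: Compound 4 Expected

This account rests on a few compounds, and the source may have more. Where it says the series, first, only, none or still open, it means among the compounds named here.

Three compounds sharing one core have been measured in a functional assay on Jurkat cells for inhibition of nuclear factor NF-kappa-B complex (Homo sapiens); on this read-out lower numbers stand for stronger inhibition and higher numbers for weaker inhibition:

Compound 1 `CCOC(=O)c1cnc(-c2cnc3ccccc3c2)nc1NN1C(=O)C=C(C)C1=O` gives 6000 nM.
Compound 2 `CCOC(=O)c1cnc(-n2nc(C)cc2C)nc1NN1C(=O)C=C(C)C1=O` gives 10000 nM.
Compound 3 `CCOC(=O)c1cnc(-c2cccc([N+](=O)[O-])c2)nc1NN1C(=O)C=C(C)C1=O` gives 7000 nM.

Compound 2 shows the highest number of the three, yet its distances to the others are small: a 1.4-fold lower number from compound 2 to compound 3 (0.15 log units; within the scatter), and the step from compound 1 to compound 2 is a 1.7-fold higher number from compound 1 to compound 2 (0.22 log units; within the scatter). The third comparison, a 1.2-fold higher number from compound 1 to compound 3 (0.07 log units; within the scatter), is equally flat. All three steps exchange the group on the same aromatic carbon of the shared core, and none of them moves the number beyond the scatter.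

Compound 4 `CCOC(=O)c1cnc(Cc2ccccc2)nc1NN1C(=O)C=C(C)C1=O` carries the same exchange once more: benzyl in place of 3,5-dimethyl-1H-pyrazol-1-yl on an aromatic carbon. Because the three measured exchanges at this position gave a 1.7-fold higher number from compound 1 to compound 2 (0.22 log units; within the scatter), a 1.2-fold higher number from compound 1 to compound 3 (0.07 log units; within the scatter) and a 1.4-fold lower number from compound 2 to compound 3 (0.15 log units; within the scatter), no step beyond the scatter is expected here either, and the estimated step is a 1.3-fold lower number from compound 2 to compound 4 (0.10 log units; within the scatter). Compound 4 is therefore expected to give about 8000 nM, most likely between 3000 nM and 25000 nM.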

Compound 4, half-maximal inhibitory concentration: 7000 nM
Beside the measured number, compound 4's estimate is 1.1-fold (0.06 log units) above it; measured number inside the range.
By their numbers in this assay, from the lowest: compounds 1, 3, 4 and 2 (each within the scatter of the next).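

In this assay, the position para to an ethoxycarbonyl group also accepts benzyl, whose ring is held off the core by a methylene link rather than joined to it directly, and the number stays within the scatter of all three earlier compounds (a 1.4-fold lower number from compound 2 to compound 4 (0.15 log units; within the scatter); no change at the digits printed from compound 3 to compound 4 (within the scatter); a 1.2-fold higher number from compound 1 to compound 4 (0.07 log units; within the scatter)). The change to compound 4 also removes the ring nitrogens and hydrogen-bond acceptors of 3,5-dimethyl-1H-pyrazol-1-yl, and this too leaves the number within the scatter. Nothing shown offers an explanation for this flat result.

As far as these compounds go, whether an amine, a carboxylic acid or a longer alkyl chain at this position would move the number beyond the scatter remains open. From the compounds shown here alone, all four compounds also share the ethoxycarbonyl group, so what a change to that group would do remains open as well.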